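The source may hold more compounds than are shown below. What is called first, only, known or untested is meant among the compounds shown, and "the series" means these compounds.

Measured compounds in an ADME assay on Caco-2 cells (Homo sapiens) for permeability, in the apical to basolateral direction; a lower number here means that the compound crosses the layer more slowly, a higher number that the compound crosses the layer faster:

compound 1 `Cn1cncc1CN1CC(N(CC2CCN(C(=O)C(C)(C)C)CC2)S(=O)(=O)c2ccccn2)Cc2cc(C#N)ccc21` — 0.5 10^-6 cm/s
compound 2 `Cn1cncc1CN1CC(N(CC2CCN(C(=O)C3CC3)CC2)S(=O)(=O)c2ccccn2)Cc2cc(C#N)ccc21` — 0.5 10^-6 cm/s
compound 3 `Cn1cnc(S(=O)(=O)N(Cc2cccc(-n3cccc3)c2)C2Cc3cc(C#N)ccc3N(Cc3cncn3C)C2)c1` — 0.2 10^-6 cm/s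

Compound 2 stands level with compound 1 at the digits shown, the two together the highest of the three numbers; compound 3 sits lower, and that gap is beyond the scatter. Compound 4 `Cn1cncc1CN1CC(N(CC2CCN(C(=O)N3CCCCC3)CC2)S(=O)(=O)c2ccccn2)Cc2cc(C#N)ccc21` differs from compound 2 by piperidin-1-yl in place of cyclopropyl on a carbonyl carbon. Within the data shown here, the one measured step at the same place on a carbonyl carbon is no change at the digits printed from compound 1 to compound 2 (within the scatter), which stayed within the scatter. Among the measured compounds shown here, no other measured pair touches this position. On that basis the expected step from compound 2 in this assay is none beyond the scatter, no change at the digits printed from compound 2 to compound 4 (within the scatter). Compound 4 is therefore estimated at 0.5 10^-6 cm/s, with a range from 0.2 10^-6 cm/s to 1.2 10^-6 cm/s expected.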

Compound 4, apparent permeability: 0.6 10^-6 cm/s
Compound 4: middle estimate off by 1.2-fold (0.08 log units), on the low side; measured number inside the range.
By their numbers in this assay, from the lowest: compound 3; then compounds 1, 2 and 4 (each within the scatter of the next).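

At this carbonyl carbon, the amide-type attachment of piperidin-1-yl, with its larger ring and ring nitrogen, gives no step beyond the scatter in this assay, either against cyclopropyl (a 1.2-fold higher number from compound 2 to compound 4 (0.08 log units; within the scatter)) or against tert-butyl (a 1.2-fold higher number from compound 1 to compound 4 (0.08 log units; within the scatter)). The three groups measured here therefore show no separation at this position, now across both carbon-linked and nitrogen-linked groups. No available data give a reason for this.

Still open, on these data alone, is whether a carboxylic acid or a primary amine on a longer chain at this carbonyl carbon would move the number beyond the scatter. The compounds shown also leave open whether this flat result holds with other groups elsewhere on the shared core.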